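This account rests on a few compounds, and the source may have more. Where it says the series, first, only, none or still open, it means among the compounds named here.

Compound 1 `Cc1cc(=O)oc2c1c(C)nn2C` is the reference point of the series. In a functional assay on the whole organism with Mus musculus as the target, in the writhing test (a lower number here means that less compound is needed, a higher number that more compound is needed for the effect), compound 1 gives 11.6 mg/kg, the lowest of the two numbers in hand. Compound 3 `Cc1cc(O)oc2nncc1-2` gives 40.6 mg/kg in this assay, a gap from compound 1 that lies beyond the usual scatter. Compound 2 `Cc1cc(=O)oc2c1c(CC(=O)O)nn2C` reaches only a limit in this assay, > 100 mg/kg, not a number. Going by the values given here, the one single-point step measured so far, an at least 8.6-fold higher number from compound 1 to compound 2 (0.93 log units; beyond the scatter), introduces a carboxy group on a saturated chain carbon; it is also the only step that ends at the limit of > 100 mg/kg in this assay, at which 1 of the 3 values shown sits.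

Compound 4 `Cc1cc(=O)oc2c1c(C)nn2C(C)C` is not yet measured. It differs from compound 1 in one place: isopropyl in place of methyl on an aromatic nitrogen. Among the compounds with values here, no measured step touches the group on the aromatic nitrogen, so the carboxy step from compound 1 to compound 2 is the only comparison available, and it concerns a different group at a different place; it gives no direct guide to an isopropyl in place of a methyl. With nothing in the measured steps pointing either way, no step beyond the scatter is expected in this assay from compound 1 to compound 4, and the expected step is a 1.2-fold higher number from compound 1 to compound 4 (0.08 log units; within the scatter). Compound 4 is therefore estimated at 14 mg/kg in this assay, within a range of 5 mg/kg to 40 mg/kg.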

Compound 4, dose for half-maximal effect: > 100 mg/kg
Compound 4 was reported as a limit (the forecaster's own chance of this, stated with the estimate: 5%); middle value at least 7.1-fold (0.85 log units) from the limit.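

Going by these compounds alone, the group on the aromatic nitrogen, which no earlier step touched, proves sensitive in this assay: isopropyl in place of methyl gives an at least 8.6-fold higher number from compound 1 to compound 4 (0.93 log units; beyond the scatter). Compound 4 gives only a limit, > 100 mg/kg, so the step has a lower bound and no upper one. Methyl and isopropyl differ here only in their count of carbon, with no hydrogen-bond donor, acceptor or net charge entering, yet this change ends at the same limit as the carboxy step on the saturated chain carbon, so two unlike changes to compound 1 now stop there: the limit of > 100 mg/kg in this assay, at which 2 of the 4 values shown sit.

The compounds shown do not tell how the number moves with hydrogen or ethyl on the aromatic nitrogen, so it remains open whether methyl is the only group tolerated there or whether the loss sets in gradually with chain size. A straight propyl chain at the same nitrogen would also separate the effect of branching from that of carbon count, which methyl and isopropyl alone cannot do.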